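Second chloro on the anilino ring: step to compound 3

The compounds below may be only part of what the source reports. "The series", "measured", "known", "first", "only" and "open" are said of these compounds alone.

Measured compounds:
compound 1, `CN1CCN(CCCOc2cccc3nc(Nc4ccc(F)c(F)c4)ccc23)CC1`, 7090 nM
compound 2, `CN1CCN(CCCOc2cccc3nc(Nc4cccc(Cl)c4)ccc23)CC1`, 4650 nM

The measurements come from a functional assay on cells (Panel leukemia (Carcinoma cell lines), Homo sapiens) for inhibition, read by sulforhodamine B assay, with a stated time of 48 h; on this read-out higher numbers stand for weaker inhibition of growth and lower numbers for stronger inhibition of growth. Compound 2 gives the lowest of the two numbers, but its nearest neighbour, compound 1, sits within the scatter of it, so the two cannot be ordered. Among the compounds with values here, the only measured step, a 1.5-fold lower number from compound 1 to compound 2 (0.18 log units; within the scatter), stays within the scatter.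

Compound 3, `CN1CCN(CCCOc2cccc3nc(Nc4cc(Cl)cc(Cl)c4)ccc23)CC1`, is not yet measured. It differs from compound 2 in one place: chloro in place of hydrogen on an aromatic carbon.

Within the data shown here, no measured step shows what a second chloro group on this ring does, and the one step that touches this ring, a 1.5-fold lower number from compound 1 to compound 2 (0.18 log units; within the scatter), is within the scatter. The expectation for compound 3 therefore rests on compound 2 alone and is worded with caution: no step beyond the scatter is expected in either direction. The estimated step is a 1.2-fold lower number from compound 2 to compound 3 (0.07 log units; within the scatter). Compound 3 is expected to give about 4000 nM, with a range from 1500 nM to 12000 nM.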

Compound 3, concentration for total growth inhibition: 3960 nM
The estimate for compound 3 lay 1.0-fold (0.00 log units) above the measured number; the measured number falls inside the stated range.
By their numbers in this assay, from the lowest: compounds 3, 2 and 1 (each within the scatter of the next).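

In this assay, the change from 3-chlorophenyl to 3,5-dichlorophenyl gives the first measured view of a second chloro group on this ring, and a 1.2-fold lower number from compound 2 to compound 3 (0.07 log units; within the scatter) shows that this addition leaves the number within the scatter of the one-chloro compound. The comparison with the difluorinated ring reads the same way: a 1.8-fold lower number from compound 1 to compound 3 (0.25 log units; within the scatter) also stays within the scatter, so 3,4-difluorophenyl, 3-chlorophenyl and 3,5-dichlorophenyl on this nitrogen cannot be ordered by these measurements, and the halogen changes seen so far have produced no readable step. No evidence at hand bears on why these numbers stay so close.

The compounds shown leave open whether any group on this ring can move the number beyond the scatter, for example a methoxy group, a trifluoromethyl group or a nitrile in place of the added chloro group. They also leave open whether a change elsewhere in the molecule, such as a longer chain on the ether oxygen, would produce a step that can be read.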